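Fluoro in place of methylsulfanyl: an expected cytotoxicity

This account rests on a few compounds, and the source may have more. Where it says the series, first, only, none or still open, it means among the compounds named here.

Compound 1 `CSc1ccc(/C=N/n2c(Cc3ccc(S(C)(=O)=O)cc3)n[nH]c2=S)cc1`: 71.9%
Compound 2 `CS(=O)(=O)c1ccc(Cc2n[nH]c(=S)n2/N=C/c2ccccc2Cl)cc1`: 76.5%

For the measured compounds named here, in a functional assay on HeLa cells (Homo sapiens) for cytotoxicity, read by MTT assay, with a stated time of 48 h, tested at 100 uM (on this read-out higher numbers stand for a stronger effect at the one concentration tested and lower numbers for a weaker effect), compound 1 gives 71.9%, and its number sits alongside that of compound 2, since the one measured step, a number 4.6 percentage points higher from compound 1 to compound 2 (within the scatter), lies within the scatter. Compound 3 `CS(=O)(=O)c1ccc(Cc2n[nH]c(=S)n2/N=C/c2ccc(F)cc2)cc1` differs from compound 1 by fluoro in place of methylsulfanyl on an aromatic carbon. Going by the values given here, the only step that bears on this position, changing the group on the carbon with a double bond to nitrogen, was within the scatter, so no step beyond the scatter is expected: a number 1.1 percentage points higher from compound 1 to compound 3 (within the scatter). For compound 3 the estimate is therefore 73%, expected between 60% and 86%.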

Compound 3, a percentage reported as activity, at one concentration (the size of the read-out at that concentration, not a potency): 57.8%
The estimate for compound 3 lay 15.2 percentage points above the measured number; the measured number lies below the stated range.
By their numbers in this assay, from the lowest: compound 3; then compounds 1 and 2 (each within the scatter of the next).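

In this assay this position is not indifferent after all: fluoro in place of methylsulfanyl gives a number 14.1 percentage points lower from compound 1 to compound 3 (beyond the scatter), whereas the earlier change to 2-chlorophenyl stayed within the scatter. The step of a number 18.7 percentage points lower from compound 2 to compound 3 (beyond the scatter) shows that 4-fluorophenyl and 2-chlorophenyl also part on this read-out, so the group on the carbon with a double bond to nitrogen can shift the number. Nothing at hand accounts for the drop.

As far as these compounds go, whether it belongs to fluoro itself or to the loss of methylsulfanyl stays open. So does how an amine or a carboxylic acid would read in the same place.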